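The source may report more compounds than this note shows. Statements on the series, on what has been measured and on what is new or still open speak of the compounds shown alone.

Of the compounds shown here, two have been measured so far. Compound 1 `Nc1cccc(CNc2cc(C(F)(F)F)cc3[nH]ncc23)c1` gives 89% in an assay for inhibition of Tryptophan 2,3-dioxygenase (Homo sapiens), with stated times of 10 min and 60 min, tested at 100 uM; a higher number here means a stronger effect of the compound at the concentration tested, a lower number a weaker effect. Compound 2 `NCCn1ncc2c(NCc3ccccc3[N+](=O)[O-])cc(C(F)(F)F)cc21` gives 29% in this assay, the lower of the two numbers, with a gap to compound 1 that lies beyond the usual scatter. Compound 3 `CC(C)n1ncc2c(NCc3ccccc3[N+](=O)[O-])cc(C(F)(F)F)cc21` is not yet measured; it differs from compound 2 in one place: isopropyl in place of 2-aminoethyl on an aromatic nitrogen. Among the compounds with values here, no measured pair of the series shows a change of this kind, so nothing is known about its size. In this assay the expected step is small, within the scatter or at most a modest rise: a number 11 percentage points higher from compound 2 to compound 3 (beyond the scatter). Compound 3 is expected to give about 40%, between 15% and 70%.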

Compound 3, a percentage reported as inhibition, at one concentration (the size of the read-out at that concentration, not a potency): 32%
Compound 3: middle estimate off by 8 percentage points, on the high side; measured number inside the range.
By their numbers in this assay, from the lowest: compounds 2 and 3 (each within the scatter of the next); then compound 1.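

In this assay, within the data shown here, isopropyl in place of 2-aminoethyl on an aromatic nitrogen gives a number 3 percentage points higher from compound 2 to compound 3 (within the scatter) and so offers the first reading of a change at this position. The hydrogen-bond donor and acceptor counted in 2-aminoethyl are absent from isopropyl, at the same heavy-atom count, yet the read-out does not separate the two groups. No measurement at hand bears on why. Open, as far as these compounds go, is how a carboxylic acid or a longer chain on this nitrogen would read, and how compound 3 would read with this nitrogen unsubstituted.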